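The source may hold more compounds than are shown below. What is called first, only, known or untested is meant among the compounds shown, and "the series" means these compounds.

Going by the values given here, compound 3 `COc1ccc(-c2cc(-c3ccc(-n4cccn4)cc3)cnc2N)cn1` stands highest of the three numbers so far in a physicochemical assay for lipophilicity, at pH 7.4 (on this read-out higher numbers stand for higher lipophilicity and lower numbers for lower lipophilicity), giving 3.1. Nearest is compound 1 `COc1ccc(-c2cc(-c3ccc(S(=O)(=O)N(C)C)cc3)cnc2N)cn1`, which gives 2.8; furthest is compound 2 `CNS(=O)(=O)c1ccc(-c2cnc(N)c(-c3ccc(OC)nc3)c2)cc1`, which gives 2.2. Compound 4 `COc1ccc(-c2cc(-c3ccc(C(N)=O)cc3)cnc2N)cn1` differs from compound 3 by carbamoyl in place of 1H-pyrazol-1-yl on an aromatic carbon. Among the compounds with values here, two measured steps bear on this change: a number 0.30 log units higher from compound 1 to compound 3 (within the scatter) and a number 0.90 log units higher from compound 2 to compound 3 (beyond the scatter). Within the sulfamoyl pair, a number 0.60 log units lower from compound 1 to compound 2 (beyond the scatter). The entering carbamoyl carries one hydrogen-bond donor, as does the methylsulfamoyl of compound 2 with its 2.2, so a downward step of about that size, reversed, is expected here. Compound 4 is therefore estimated at 2, with a range of 1.5 to 2.5, meaning an expected step of a number 1.10 log units lower from compound 3 to compound 4 (beyond the scatter).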

Compound 4, distribution coefficient: 1.7
For compound 4 the middle estimate is 0.30 log units above the measured one; measured number inside the range.
By their numbers in this assay, from the lowest: compound 4; then compound 2; then compounds 1 and 3 (each within the scatter of the next).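

In this assay carbamoyl on this aromatic carbon gives the lowest number of the series, with a number 1.40 log units lower from compound 3 to compound 4 (beyond the scatter) and a number 1.10 log units lower from compound 1 to compound 4 (beyond the scatter). Compound 2 also carries a hydrogen-bond donor on this carbon, yet a number 0.50 log units lower from compound 2 to compound 4 (beyond the scatter) shows that the presence of a donor does not alone set the number here. No measurement at hand explains these steps.

Going by these compounds, whether dimethylcarbamoyl would raise the number relative to carbamoyl, as dimethylsulfamoyl does relative to methylsulfamoyl, remains open. Where a carboxylic acid or an amine on this carbon would fall also remains open.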